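Ethyl for methyl on the core of compound 1

A few compounds are considered here, and "the series" means these few. Any claim that something is new, unique, unknown or untested is made for them only; others in the source may bear on it.

Compound 1 `CC(=O)n1nc(C)c(-c2ccc(Cl)c(Cl)c2)c1N` gives 8400 nM in an assay on Sf9 cells for inhibition of mitogen-activated protein kinase kinase kinase 14 (Homo sapiens), read by ADP-Glo, with a stated time of 60 min; a lower number here means a stronger inhibitor, a higher number a weaker inhibitor. Compound 2 `Cc1nn(C(=O)C2CCC2)c(N)c1-c1ccc(Cl)c(Cl)c1` gives 2900 nM. Compound 3 `Cc1nn(C(=O)C2CCCC2)c(N)c1-c1ccc(Cl)c(Cl)c1` gives 41000 nM.

Among the three numbers, compound 1 stands second highest. The steps of a 2.9-fold lower number from compound 1 to compound 2 (0.46 log units; beyond the scatter) and a 4.9-fold higher number from compound 1 to compound 3 (0.69 log units; beyond the scatter) both alter the group on the carbonyl carbon, and a 14-fold higher number from compound 2 to compound 3 (1.15 log units; beyond the scatter) does the same. Compound 4 `CCc1nn(C(C)=O)c(N)c1-c1ccc(Cl)c(Cl)c1` differs from compound 1 by methyl in place of hydrogen on a saturated chain carbon bound to an aromatic carbon. Going by the values given here, none of the measured steps touches this position, so no measured step bears on the change, and no direction can be read from them. Compound 4 is therefore expected to sit close to compound 1, with a step of no change at the digits printed from compound 1 to compound 4 (within the scatter) that is not expected to go beyond the scatter. The estimate for compound 4 is 8400 nM, within a range of 3000 nM to 24000 nM.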

Compound 4, half-maximal inhibitory concentration: > 100000 nM
Compound 4 ended at the assay's limit; the forecaster's own chance of this, stated with the estimate: 5%; at least 11-fold (1.07 log units) between middle value and limit.
By their numbers in this assay, from the lowest: compound 2; then compound 1; then compound 3. At a limit, above all of these: compound 4.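

The methyl on the core of compound 1 turns out not to be a silent position in this assay: changing it to ethyl gives an at least 11-fold higher number from compound 1 to compound 4 (1.07 log units; beyond the scatter). A change of a single carbon here therefore moves the result as clearly as the larger changes on the carbonyl carbon did. Compound 4 stands at a limit of the assay, not at a number: the limit of > 100000 nM in this assay, at which 1 of the 4 values shown sits.

From the compounds shown here alone, what remains open is how hydrogen, a longer chain or an amine would read in place of this methyl. Going by these compounds, it is also open whether ethyl would shift the cyclobutyl compound 2 in the same way.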